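Urea-hydrazone series: pyrrole amine tail variation

The source may report more compounds than this note shows. Statements on the series, on what has been measured and on what is new or still open speak of the compounds shown alone.

Measured so far:
compound 1, `O=C(N/N=C/c1ccc(Cl)c(Cl)c1)Nc1ccc(Oc2ccnc3[nH]ccc23)c(F)c1`, 2650 nM
compound 2, `CN(C)CCn1cccc1/C=N/NC(=O)Nc1ccc(Oc2ccnc3[nH]ccc23)c(F)c1`, "not active" (no number reported)

In a functional assay on A549 cells (Homo sapiens) for antiproliferative activity, read by MTT assay, with a stated time of 72 h (on this read-out higher numbers stand for weaker inhibition and lower numbers for stronger inhibition), compound 1 gives 2650 nM, a moderate value. In this assay compound 2 is recorded as "not active" (no number reported), so no single number marks where compound 2 stands; it can only be placed as weaker than the measured range that compound 1 occupies, without a size for that gap.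

Compound 3, `CCN(CC)CCCn1cccc1/C=N/NC(=O)Nc1ccc(Oc2ccnc3[nH]ccc23)c(F)c1`, is the next member to be measured. It differs from compound 2 in one place: (diethylamino)methyl in place of dimethylamino on a saturated chain carbon, two bonds along the chain from an aromatic nitrogen. Compound 2 gives no number from which a step could be computed, so no direction is fixed by the data; with compound 2 inactive, the expectation for compound 3 in this assay is a step of no more than the usual scatter, with a real chance that only a limit is returned again. Compound 3 is expected at 15000 nM, within 4000 nM to 60000 nM.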

Compound 3, half-maximal inhibitory concentration: 1210 nM
For compound 3 the middle estimate is 12-fold (1.09 log units) above the measured one; the whole stated range lies above it.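

In this assay, for the compounds shown here, compound 3 gives 1210 nM, while compound 2 has no number, so no step between compound 2 and compound 3 can be read. The compounds shown leave open how large the effect of exchanging 2-(dimethylamino)ethyl for 3-(diethylamino)propyl is. No available evidence bears on this result.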